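Swapping the amine tail on a bradykinin receptor ligand

A few compounds are considered here, and "the series" means these few. Any claim that something is new, unique, unknown or untested is made for them only; others in the source may bear on it.

Measured compounds:
- compound 1, `CCN(CC)CCN1CCN(C(=O)COCCN(C)S(=O)(=O)c2c(C)cc(OC)cc2C)CC1`: 10 nM
- compound 2, `Cc1c(Cl)ccc(S(=O)(=O)N(C)CCCCC(=O)N(C)Cc2ccc(C3=NCCN3)cc2)c1Cl`: "not determined" (no result reported)

Going by the values given here, compound 1 is the only compound with a number here. In an assay on HEK293 cells for displacement of a labelled ligand from B1 bradykinin receptor (Homo sapiens), read by scintillation counting (on this read-out lower numbers stand for stronger inhibition and higher numbers for weaker inhibition), compound 1 gives 10 nM. In this assay, among the compounds with values here, compound 2 is recorded as "not determined" (no result reported), so nothing can be said about how the two compare, and no step between measured compounds is available.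

Compound 3, `COc1cc(C)c(S(=O)(=O)N(C)CCOCC(=O)N2CCN(CCCN(C)C)CC2)c(C)c1`, is the unmeasured compound. It differs from compound 1 in one place: (dimethylamino)methyl in place of diethylamino on a saturated chain carbon, two bonds along the chain from an amine nitrogen in a ring. The core shared with compound 1 and the aryl sulfonamide end are unchanged; only the terminal amine and the chain that carries it are reshaped, with one fewer heavy atom overall and the same count of donors and acceptors.

Within the data shown here, with no measured step to lean on, the expectation for compound 3 rests on compound 1 at 10 nM and the modest size of the change. Compound 3 is expected to stay close, with a step of a 1.5-fold higher number from compound 1 to compound 3 (0.18 log units; within the scatter) that lies within the usual scatter rather than beyond it. The estimate for compound 3 in this assay is 15 nM, in the range 4 nM to 50 nM.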

Compound 3, inhibition constant: 5.8 nM
Compound 3: middle estimate off by 2.6-fold (0.41 log units), on the high side; low and high end bracket the measured number.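

In this assay, putting (dimethylamino)methyl in place of diethylamino, on a saturated chain carbon two bonds along the chain from an amine nitrogen in a ring, gives a 1.7-fold lower number from compound 1 to compound 3 (0.24 log units; within the scatter), so the two compounds cannot be told apart on this read-out. Going by these compounds alone, this is the first sign that this position can accept a reshaped tail: 2-(diethylamino)ethyl and 3-(dimethylamino)propyl, which differ in both the groups on the terminal nitrogen and the length of the chain carrying it, give binding that is indistinguishable here. No supporting data are available to explain this match.

This single step cannot show whether chain length and the groups on the nitrogen each have little effect or whether their separate effects happen to cancel, since both change at once. It also leaves open how far the tail can be pushed, for example whether a primary amine, a hydroxyl group in place of the terminal amine, or a longer chain would keep binding in the same range.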